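Pentyl in place of methoxy: a step awaiting measurement

The source may hold more compounds than are shown below. What is called first, only, known or untested is meant among the compounds shown, and "the series" means these compounds.

Measured so far in a functional assay on A549 cells (Homo sapiens) for antiproliferative activity, read by MTT assay, with a stated time of 72 h; on this read-out higher numbers stand for weaker inhibition and lower numbers for stronger inhibition:
Compound 1, `Cc1ccc(S(=O)(=O)NCc2cn(C[C@H](O)[C@H]3OC(=O)C(OCc4ccccc4)=C3OCc3ccccc3)nn2)cc1`, gives 16800 nM.
Compound 2, `COc1ccc(-c2cn(C[C@H](O)[C@H]3OC(=O)C(OCc4ccccc4)=C3OCc3ccccc3)nn2)cc1`, gives 28300 nM.
Compound 3, `COc1ccccc1-c1cn(C/C=C2\OC(=O)C(OCc3ccccc3)=C2OCc2ccccc2)nn1`, gives only a limit, > 100000 nM.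

Compound 2 stands close to compound 1, the step being a 1.7-fold higher number from compound 1 to compound 2 (0.23 log units; within the scatter). Compound 3 sits at the limit of > 100000 nM in this assay, at which 1 of the 3 values shown sits, and that is a limit rather than a number. Compound 4, `CCCCCc1ccc(-c2cn(C[C@H](O)[C@H]3OC(=O)C(OCc4ccccc4)=C3OCc3ccccc3)nn2)cc1`, differs from compound 2 in one place: pentyl in place of methoxy on an aromatic carbon. Among the compounds with values here, no measured step touches this group; the single measured step, from a different exchange, lies within the scatter, so for compound 4 no step beyond the scatter is expected in this assay. Compound 4 is therefore expected near 25000 nM, with a range from 8000 nM to 80000 nM. That corresponds to an expected 1.1-fold lower number from compound 2 to compound 4 (0.05 log units; within the scatter).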

Compound 4, half-maximal inhibitory concentration: 6220 nM
Compound 4: middle estimate off by 4.0-fold (0.60 log units), on the high side, and the stated range ends above it.
By their numbers in this assay, from the lowest: compound 4; then compounds 1 and 2 (each within the scatter of the next). At a limit, above all of these: compound 3.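

In this assay the group on this aromatic carbon proves to matter, with a 4.5-fold lower number from compound 2 to compound 4 (0.66 log units; beyond the scatter) for pentyl in place of methoxy. Within the data shown here, compound 4 also separates from the sulfonamide-bearing compound, with a 2.7-fold lower number from compound 1 to compound 4 (0.43 log units; beyond the scatter) and so, unlike the one earlier step, this exchange lies beyond the scatter. Nothing available here explains either step. As far as these compounds go, whether a longer chain, a shorter one such as ethyl, or an amine on this carbon would go further remains open. A single pair cannot show whether the number follows chain length.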